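The compounds below may be only part of what the source reports. "The series", "measured", "known", "first", "only" and "open" are said of these compounds alone.

In a functional assay on HCT-116 cells (Homo sapiens) for cytotoxicity, read by MTT assay, with a stated time of 48 h (on this read-out higher numbers stand for weaker inhibition and lower numbers for stronger inhibition), compound 1 `O=C(/C=C/c1ccc2c(c1)B(O)OC2)c1ccc(Cl)cc1` gives 9300 nM, the lower of the two numbers measured, though compound 2 `CCc1ccc(C(=O)/C=C/c2ccc3c(c2)B(O)OC3)cc1`, which gives 10900 nM, lies within the scatter of it. Among the measured compounds shown here, the one measured step, a 1.2-fold higher number from compound 1 to compound 2 (0.07 log units; within the scatter), shows a change at the ring position that stayed within the scatter. Compound 3 `CCOC(=O)c1ccc(C(=O)/C=C/c2ccc3c(c2)B(O)OC3)cc1` carries ethoxycarbonyl in place of chloro on an aromatic carbon. For the measured compounds named here, no measured step involves an ethoxycarbonyl, so only the flat step at this same place guides the expectation. The expected step of a 1.1-fold higher number from compound 1 to compound 3 (0.03 log units; within the scatter) therefore stays within the scatter. Compound 3 is expected to give 10000 nM, in a range from 4000 nM to 25000 nM.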

Compound 3, half-maximal inhibitory concentration: 7600 nM
Estimate against measurement, compound 3: 1.3-fold (0.12 log units) above, within the range that was stated.
By their numbers in this assay, from the lowest: compounds 3, 1 and 2 (each within the scatter of the next).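

In this assay the position para to a large group tolerates the much larger ethoxycarbonyl without leaving the scatter (a 1.2-fold lower number from compound 1 to compound 3 (0.09 log units; within the scatter); a 1.4-fold lower number from compound 2 to compound 3 (0.16 log units; within the scatter)). Thus a group of five heavy atoms carrying hydrogen-bond acceptors reads the same as chloro or ethyl, which the earlier pair, neither member of which has such acceptors, could not show. No evidence is available that bears on this flat result.

As far as these compounds go, whether an amine or a carboxylic acid here would move the number beyond the scatter stays open. So does whether any change at this position matters in this assay at all.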